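The compounds below may be only part of what the source reports. "The series", "measured", "known", "first", "only" and "open" are said of these compounds alone.

Series notes. Compound 1 `O=[N+]([O-])c1ccc2[nH]c(-c3ccc(C(F)(F)F)cc3)nc2c1` carries trifluoromethyl on the pendant ring and a nitro group on the shared core. In a functional assay for antagonist activity at Neuropeptides B/W receptor type 1 (Homo sapiens), read by cAMP accumulation (on this read-out higher numbers stand for weaker inhibition and lower numbers for stronger inhibition), compound 1 gives only a limit, > 31600 nM, and no number. Compound 1 therefore stands at the limit of > 31600 nM in this assay, at which 1 of the 2 values shown sits. Compound 2 `FC(F)(F)c1ccc2[nH]c(-c3ccc(-c4nnc[nH]4)cc3)nc2c1` in this assay gives 3080 nM; it differs from compound 1 in more than one place, so the two values are only set side by side. Compound 3 `CC(=O)c1ccc(-c2nc3cc([N+](=O)[O-])ccc3[nH]2)cc1` brings one change: acetyl in place of trifluoromethyl on an aromatic carbon. Among the measured compounds shown here, no measured step of this kind exists; the step from compound 1 to compound 3 is expected as an at least 1.5-fold lower number from compound 1 to compound 3 (0.19 log units; that floor lies within the scatter), direction and size uncertain. Compound 3 is expected near 20000 nM, between 4000 nM and 60000 nM.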

Compound 3, half-maximal inhibitory concentration: 9320 nM
Compound 3: middle estimate off by 2.1-fold (0.33 log units), on the high side; the range from low to high includes it.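

In this assay, acetyl in place of trifluoromethyl on an aromatic carbon, with the nitro group on the shared core kept, gives an at least 3.3-fold lower number from compound 1 to compound 3 (0.53 log units; beyond the scatter). This is the only single-place step shown, and it shows that the read-out at this position responds to the group placed there. The step is a floor and not a full size, as compound 1 gives only a limit: the limit of > 31600 nM in this assay, at which 1 of the 3 values shown sits.

Whether the carbonyl of acetyl or the loss of trifluoromethyl accounts for the step stays open, and an amide, a carboxylic acid or a longer ketone chain here would bear on that. As far as these compounds go, whether the step carries over to a core with trifluoromethyl in place of nitro also stays open.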